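The source may hold more compounds than are shown below. What is called first, only, known or untested is meant among the compounds shown, and "the series" means these compounds.

Measured so far in an ADME assay on Raji cells (Homo sapiens) for cytotoxicity, read by CellTiter-Glo and resazurin assay, with a stated time of 72 h; on this read-out lower numbers stand for an effect already at smaller amounts and higher numbers for an effect only at larger amounts of compound:
Compound 1, `CC(C)N(Cc1cccc(OCCCCCC(=O)O)c1)C(=O)c1ccc(-c2cccc(C(F)(F)F)c2)cc1`, gives > 26000 nM, a limit of the assay rather than a number.
Compound 2, `CCOC(=O)CCCCCOc1cccc(CN(C(=O)c2ccc(-c3ccoc3)cc2)C(C)C)c1`, gives > 26000 nM, likewise a limit and not a number.

Going by the values given here, compound 2 therefore stands where the only other value shown also stands: both sit at the limit of > 26000 nM in this assay, at which 2 of the 2 values shown sit, so the two values show no ranking and leave no measured step to lean on. Compound 3, `CCOC(=O)CCCCCOc1cccc(CN(C(=O)c2ccc(-c3cccc(CC(=O)O)c3)cc2)C(C)C)c1`, differs from compound 2 in one place: 3-(carboxymethyl)phenyl in place of furan-3-yl on an aromatic carbon. Among the compounds with values here, no step between measured compounds is recorded, so the size of the change from compound 2 to compound 3 can only be expected, not read off. Compound 1, which also bears a carboxylic acid, gives only the limit > 26000 nM, and on that ground the acid entering in compound 3 is not expected to pull the cytotoxicity into the measured range. The step that the limit leaves unreadable from compound 2 to compound 3 is expected to be none beyond the scatter, with another limit the most likely outcome. For compound 3 the estimate is 40000 nM, in the range 15000 nM to 100000 nM.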

Compound 3, half-maximal effective concentration: > 26000 nM
Compound 3: a limit, no number (the forecaster's own chance of this, stated with the estimate: 85%); the middle value does not contradict the limit.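

No step can be read from compound 2 to compound 3 in this assay, because both compounds give only a limit and no number: the limit of > 26000 nM in this assay, at which 3 of the 3 values shown sit.

The compounds shown leave open how large the effect of 3-(carboxymethyl)phenyl in place of furan-3-yl is, and whether any compound of this kind reaches the measured range.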